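Hydroxyphenyl in place of chlorophenyl on the shared core

The compounds below may be only part of what the source reports. "The series", "measured", "known", "first", "only" and "open" are said of these compounds alone.

Going by the values given here, compound 3 `CC(C)CCn1cnc2c(Nc3ccc(Cl)cc3)nc(N[C@H]3CC[C@H](N)CC3)nc21` carries a 4-chlorophenyl group on the shared core and in a functional assay on BT-474 cells (Homo sapiens) for inhibition, read by fluorescence, with a stated time of 72 h (on this read-out higher numbers stand for weaker inhibition of growth and lower numbers for stronger inhibition of growth), compound 3 gives 5100 nM, the lowest of the three numbers so far, though within the scatter of both neighbours. Compound 2 `CC(C)CCn1cnc2c(NCc3cccc(Cl)c3)nc(N[C@H]3CC[C@H](N)CC3)nc21` gives 6600 nM and compound 1 `CCCCCCn1cnc2c(Nc3ccc(O)cc3)nc(N[C@H]3CC[C@H](N)CC3)nc21` gives 7700 nM. Among the compounds with values here, the only single-point step measured is a 1.3-fold lower number from compound 2 to compound 3 (0.11 log units; within the scatter), and it changes a different part of the molecule.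

Compound 4 `CC(C)CCn1cnc2c(Nc3cccc(O)c3)nc(N[C@H]3CC[C@H](N)CC3)nc21` differs from compound 3 as follows: 3-hydroxyphenyl in place of 4-chlorophenyl on a nitrogen on an aromatic ring. Within the data shown here, no measured step isolates this change. The nearest comparison is compound 1 against compound 3, which differ in two places at once: compound 1 carries a 4-hydroxyphenyl group and a hexyl chain where compound 3 carries a 4-chlorophenyl group and a 3-methylbutyl chain, and their two numbers lie within the scatter of each other. That gives no sign that a hydroxyl on the phenyl ring moves this assay beyond the scatter, so the expected step of a 1.2-fold higher number from compound 3 to compound 4 (0.07 log units; within the scatter) is not expected to exceed the scatter in either direction. Compound 4 is therefore estimated at 6000 nM, with a range from 2500 nM to 14000 nM in this assay.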

Compound 4, concentration for 50% growth inhibition: 14700 nM
The estimate for compound 4 lay 2.5-fold (0.39 log units) below the measured number; the measured number lies above the stated range.
By their numbers in this assay, from the lowest: compounds 3, 2, 1 and 4 (each within the scatter of the next, the first and the last beyond it).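

The group on a nitrogen on an aromatic ring can move the number in this assay beyond the scatter, which the earlier step at this place (a 1.3-fold lower number from compound 2 to compound 3 (0.11 log units; within the scatter)) did not show. 3-Hydroxyphenyl separates from 4-chlorophenyl (a 2.9-fold higher number from compound 3 to compound 4 (0.46 log units; beyond the scatter)) and also from 3-chlorobenzyl (a 2.2-fold higher number from compound 2 to compound 4 (0.35 log units; beyond the scatter)), both modest steps towards weaker inhibition of growth, while the two chlorine-bearing groups themselves stay within the scatter of each other. The data give no explanation for this shift.

The step from compound 3 to compound 4 changes both the substituent and its numbered ring position, so the hydroxyl and its placement cannot be told apart here; 3-chlorophenyl and 4-hydroxyphenyl, each with the 3-methylbutyl chain, would separate the two. On these data alone, it also remains open whether the step is particular to the hydroxyl, or whether a 3-methoxyphenyl or 3-aminophenyl group on the same nitrogen would give a number closer to that of compound 3 or to that of compound 4.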